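The compounds below may be only part of what the source reports. "The series", "measured", "known", "first", "only" and "open" are said of these compounds alone.

Measured in a functional assay on MCF cells (Homo sapiens) for antiproliferative activity, with a stated time of 72 h; on this read-out higher numbers stand for weaker inhibition and lower numbers for stronger inhibition:
Compound 1 `OC[C@H]1O[C@@H](n2cnc3c(NCc4ccccc4Cl)ncnc32)[C@H](O)[C@@H]1O`: > 166000 nM (a limit, not a number)
Compound 2 `Cc1cccc(CNc2ncnc3c2ncn3[C@@H]2O[C@H](CO)[C@@H](O)[C@H]2O)c1O`: 6900 nM

Among the compounds with values here, compound 2 holds the only actual number so far, 6900 nM. For compound 1 there is only (the limit of > 166000 nM in this assay, at which 1 of the 2 values shown sits).

Compound 3 `OC[C@H]1O[C@@H](n2cnc3c(NCc4ccccc4OC(F)F)ncnc32)[C@H](O)[C@@H]1O` differs from compound 2 in one place: 2-(difluoromethoxy)phenyl in place of 2-hydroxy-3-methylphenyl on a saturated chain carbon bound to a nitrogen on an aromatic ring. Within the data shown here, one measured step bears on this change. It is an at least 24-fold lower number from compound 1 to compound 2 (1.38 log units; beyond the scatter), a large step beyond the scatter, in which 2-hydroxy-3-methylphenyl replaced 2-chlorophenyl at the same place. Compound 3 gives up that same group, so the gain seen in an at least 24-fold lower number from compound 1 to compound 2 (1.38 log units; beyond the scatter) is expected to be largely lost, although a different group enters here. A clear rise in this assay is therefore expected, meaning weaker inhibition. The estimated step is a 5.8-fold higher number from compound 2 to compound 3 (0.76 log units; beyond the scatter). A reading that is only a limit also remains possible. For compound 3 the estimate is 40000 nM, with an expected range of 9000 nM to 166000 nM.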

Compound 3, half-maximal inhibitory concentration: > 166000 nM
Compound 3: a limit, no number; the forecaster's own chance of this, stated with the estimate: 40%; middle value at least 4.1-fold (0.61 log units) from the limit.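

In this assay, within the data shown here, placing 2-(difluoromethoxy)phenyl in place of 2-hydroxy-3-methylphenyl gives an at least 24-fold higher number from compound 2 to compound 3 (1.38 log units; beyond the scatter), so 2-chlorophenyl is no longer the only group at this place that fails to give a measurable value. Among the three compounds, only compound 2 carries a hydrogen-bond donor on this aromatic ring and only compound 2 gives an actual number, although three compounds cannot establish a rule. Compound 1 and compound 3 both stop at the same limit, which is not a number, and the step between them cannot be read: the limit of > 166000 nM in this assay, at which 2 of the 3 values shown sit.

The compounds shown leave open whether the hydroxyl, the methyl or the two together in compound 2 account for its value. A phenyl ring bearing only the hydroxyl or only the methyl would separate these, and an amine in place of the hydroxyl would test how specific that group is.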